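The source may report more compounds than this note shows. Statements on the series, on what has been measured and on what is new or still open speak of the compounds shown alone.

Compound 1 `CNc1nc(NCCCN(C)C)c2sc(-c3ccc(C(F)(F)F)cc3)cc2n1` gives 240 ug/mL in a physicochemical assay for solubility, at pH 2 (on this read-out higher numbers stand for higher solubility and lower numbers for lower solubility), the top of the two numbers shown, though compound 2 sits within the scatter of it. Compound 2 `CNc1nc(NC2CC2)c2sc(-c3ccc(C(F)(F)F)cc3)cc2n1` gives 120 ug/mL, and the step of a 2.0-fold lower number from compound 1 to compound 2 (0.30 log units; within the scatter). Compound 3 `CNc1nc(NC2CCOCC2)c2sc(-c3ccc(C(F)(F)F)cc3)cc2n1` returns only a limit, < 5 ug/mL, the assay floor noted as the limit of < 5 ug/mL in this assay, at which 1 of the 3 values shown sits. The steps of an at least 48-fold lower number from compound 1 to compound 3 (1.68 log units; beyond the scatter) and an at least 24-fold lower number from compound 2 to compound 3 (1.38 log units; beyond the scatter) are the large movements in the set. Compound 4 `CN(C)CCCNc1nc(N2CCNCC2)nc2cc(-c3ccc(C(F)(F)F)cc3)sc12` differs from compound 1 by piperazin-1-yl in place of methylamino on an aromatic carbon. Every measured step instead varies the group on a nitrogen on an aromatic ring, which compound 4 keeps unchanged, so none bears directly on this change; no step beyond the scatter is expected, and a limit is judged unlikely. Compound 4 is therefore estimated at 250 ug/mL, range 80 ug/mL to 800 ug/mL. The expected step is a 1.0-fold higher number from compound 1 to compound 4 (0.02 log units; within the scatter).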

Compound 4, solubility: 198 ug/mL
Estimate against measurement, compound 4: 1.3-fold (0.10 log units) above; low and high end bracket the measured number.
By their numbers in this assay, from the lowest: compounds 2, 4 and 1 (each within the scatter of the next). At a limit, below all of these: compound 3.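

For the compounds shown here, the earlier compounds varied only the group on a nitrogen on an aromatic ring, whereas compound 4 is the first change on the aromatic carbon between two ring nitrogen atoms. In this assay, piperazin-1-yl in place of methylamino gives a 1.2-fold lower number from compound 1 to compound 4 (0.08 log units; within the scatter), so this carbon accepts the six-membered ring while the (3-(dimethylamino)propyl)amino group is present. Nothing shown gives a cause for this step.

Going by these compounds, whether piperazin-1-yl behaves alike alongside cyclopropyl or oxan-4-yl stays open. So does the outcome for morpholine or a longer amine chain on this carbon.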